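Swapping the amine tail in a triazole carboxamide series

The compounds below may be only part of what the source reports. "The series", "measured", "known", "first", "only" and "open" are said of these compounds alone.

Measured compounds:
- compound 1, `COc1cc2c(Oc3ccc(NC(=O)c4nnn(-c5ccc(C)cc5)c4C(F)(F)F)cc3F)ccnc2cc1OCCCN1CCC(C)CC1`, 140 nM
- compound 2, `COc1cc2c(Oc3ccc(NC(=O)c4nnn(-c5ccc(F)c(F)c5)c4C(F)(F)F)cc3F)ccnc2cc1OCCCN1CCC(C)CC1`, 50 nM
- compound 3, `COc1cc2c(Oc3ccc(NC(=O)c4nnn(-c5cccc(Br)c5)c4C(F)(F)F)cc3F)ccnc2cc1OCCCN1CCC(C)CC1`, 120 nM

In a functional assay on MKN-45 cells (Homo sapiens) for cytotoxicity, read by MTT assay, with a stated time of 72 h (a higher number here means a weaker inhibitor, a lower number a stronger inhibitor), compound 2 gives the lowest of the three numbers, and both of its neighbours lie beyond the scatter: the step of a 2.8-fold lower number from compound 1 to compound 2 (0.45 log units; beyond the scatter) and the step of a 2.4-fold higher number from compound 2 to compound 3 (0.38 log units; beyond the scatter) each separate it from the others, so on these three compounds compound 2 is the strongest inhibitor.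

Compound 4, `COc1cc2c(Oc3ccc(NC(=O)c4nnn(-c5ccc(F)c(F)c5)c4C(F)(F)F)cc3F)ccnc2cc1OCCCN1CCN(C)CC1`, keeps everything in compound 2 except one change: 4-methylpiperazin-1-yl in place of 4-methylpiperidin-1-yl on a saturated chain carbon, three bonds along the chain from an oxygen on an aromatic ring.

For the measured compounds named here, none of the measured steps bears directly on this change. The steps of a 2.8-fold lower number from compound 1 to compound 2 (0.45 log units; beyond the scatter), a 1.2-fold lower number from compound 1 to compound 3 (0.07 log units; within the scatter) and a 2.4-fold higher number from compound 2 to compound 3 (0.38 log units; beyond the scatter) all alter the aryl group on the aromatic nitrogen, while the amine tail stays the same in compounds 1, 2 and 3. The three measured compounds therefore give no information about this tail. With nothing to point in either direction, the expected step of a 1.2-fold higher number from compound 2 to compound 4 (0.08 log units; within the scatter) is no change beyond the scatter, and compound 4 is expected to give 60 nM in this assay, estimated to fall between 25 nM and 150 nM.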

Compound 4, half-maximal inhibitory concentration: 90 nM
The estimate for compound 4 lay 1.5-fold (0.18 log units) below the measured number; the measured number falls inside the stated range.
By their numbers in this assay, from the lowest: compounds 2, 4, 3 and 1 (each within the scatter of the next, the first and the last beyond it).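

For the compounds shown here, compound 4 gives the first look at the amine tail, the part held constant in compounds 1, 2 and 3. In this assay, the step of a 1.8-fold higher number from compound 2 to compound 4 (0.26 log units; within the scatter) shows that, with 3,4-difluorophenyl on the aromatic nitrogen, 4-methylpiperazin-1-yl can stand in place of 4-methylpiperidin-1-yl, adding a second hetero atom to the ring, with no difference that can be told from the scatter. Nothing available explains why the two tails give such similar numbers.

The 4-methylpiperazin-1-yl tail is shown only with 3,4-difluorophenyl, so it remains open whether it would behave the same way with 4-methylphenyl or 3-bromophenyl. Also open, as far as these compounds go, is how a morpholin-4-yl ring, or a shorter 2-(4-methylpiperazin-1-yl)ethyl chain, would compare at this position.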